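The source may report more compounds than this note shows. Statements on the series, on what has been measured and on what is new or still open speak of the compounds shown alone.

Measured so far in an assay on microsomes from brain for inhibition of Fatty-acid amide hydrolase 1 (Rattus norvegicus), read by fluorescence and HPLC, with a stated time of 60 min; on this read-out lower numbers stand for stronger inhibition and higher numbers for weaker inhibition:
compound 1 `CCCCCCCCc1ccc(OCC(=O)Cn2nnc(-c3ccccn3)n2)cc1` — 18 nM
compound 2 `CCCCCCCCc1ccc(OCC(=O)Cn2nnc(-c3ccc(C(=O)O)cc3)n2)cc1` — 90 nM

Compound 2 gives the highest of the two numbers; its nearest neighbour is compound 1, with a lower value, a gap shown as a 5.0-fold higher number from compound 1 to compound 2 (0.70 log units; beyond the scatter). Compound 3 `CCCCCCCCc1ccc(OCC(=O)Cn2nnc(-c3cccc(C(=O)O)c3)n2)cc1` differs from compound 2 by 3-carboxyphenyl in place of 4-carboxyphenyl on an aromatic carbon. Among the measured compounds shown here, no measured step moves a carboxyphenyl group between ring positions; the only step known changes the whole aromatic group, and it was modest. The step from compound 2 to compound 3 is therefore expected to stay within the scatter, no change at the digits printed from compound 2 to compound 3 (within the scatter). Compound 3 is estimated at 90 nM in this assay, with a range from 30 nM to 270 nM.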

Compound 3, half-maximal inhibitory concentration: 36 nM
Estimate against measurement, compound 3: 2.5-fold (0.40 log units) above; measured number inside the range.
By their numbers in this assay, from the lowest: compounds 1 and 3 (each within the scatter of the next); then compound 2.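

In this assay the place of the carboxylic acid on the phenyl ring counts: a 2.5-fold lower number from compound 2 to compound 3 (0.40 log units; beyond the scatter) is modest, but the 3-carboxyphenyl and 4-carboxyphenyl groups are not interchangeable at this position. With a 2.0-fold higher number from compound 1 to compound 3 (0.30 log units; within the scatter) the 3-carboxyphenyl group stands within the scatter of pyridin-2-yl, so a carboxylic acid here need not bring a measurable loss against compound 1. No available data explain the difference between the two carboxyphenyl groups.

Open, from the compounds shown here alone, is how a methyl ester, an amide or an amine in place of the carboxylic acid of compound 3 would read.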